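A few compounds are considered here, and "the series" means these few. Any claim that something is new, unique, unknown or untested is made for them only; others in the source may bear on it.

Working notes on the cytotoxicity series.

Among the measured compounds shown here, compound 3 `COc1ccc(/C=C\c2cc(OC)c(OC)c(OC)c2)cc1OCc1ccc(CNCCO)cc1` is the one member with a number in an ADME assay on NCM460 cells (Homo sapiens) for cytotoxicity, read by CCK-8 assay, with a stated time of 48 h; a higher number here means a weaker inhibitor, a lower number a stronger inhibitor: compound 3 gives 39000 nM. Compound 1 `COc1ccc(/C=C\c2cc(OC)c(OC)c(OC)c2)cc1OCc1ccc(CN[C@H](C(=O)O)[C@H](C)O)cc1` reaches only a limit of the assay, > 50000 nM. Compound 2 `COc1ccc(/C=C\c2cc(OC)c(OC)c(OC)c2)cc1OCc1ccc(CN2CCCCC2C(=O)NCCN)cc1` likewise stops at a limit, > 50000 nM. The steps read accordingly: an at least 1.2-fold lower number from compound 1 to compound 3 (0.10 log units; that floor lies within the scatter), and an at least 1.2-fold lower number from compound 2 to compound 3 (0.10 log units; that floor lies within the scatter), while a step that the two limits leave unreadable from compound 1 to compound 2 because both ends sit at the limit of > 50000 nM in this assay, at which 2 of the 3 values shown sit. Compound 3 therefore stands as the only measured point, with the other two members unresolved at the limit.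

The next member, compound 4 `COc1ccc(/C=C\c2cc(OC)c(OC)c(OC)c2)cc1OCc1ccc(CO)cc1`, differs from compound 3 in one place: hydroxy in place of (2-hydroxyethyl)amino on a saturated chain carbon bound to an aromatic carbon.

The measured steps, both floors within the scatter, give no sign that changes at this position move the number beyond noise. The expectation for compound 4 is therefore a step of a 1.2-fold higher number from compound 3 to compound 4 (0.06 log units; within the scatter), that is none beyond the scatter. Compound 4 is estimated at 45000 nM, with a range from 15000 nM to 120000 nM, and a fair chance that this assay again reports only a limit.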

Compound 4, half-maximal inhibitory concentration: > 50000 nM
Compound 4 gave a limit, no number; the forecaster's own chance of this, stated with the estimate: 50%; at least 1.1-fold (0.04 log units) between middle value and limit.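

Hydroxy in place of (2-hydroxyethyl)amino removes the amine nitrogen from this saturated chain carbon bound to an aromatic carbon, and in this assay the change gives an at least 1.2-fold higher number from compound 3 to compound 4 (0.10 log units; that floor lies within the scatter). A side group without nitrogen therefore also ends at the limit, so reaching it at this position does not depend on the amine nitrogen that compound 1 and compound 2 carry. The steps from compound 1 and from compound 2 to compound 4 cannot be read, with both ends of each step at a limit: the limit of > 50000 nM in this assay, at which 3 of the 4 values shown sit.

No step at this position is yet shown to lie beyond the scatter, and compound 3 remains the only member with a number. Open, going by these compounds, is whether a primary amine, a carboxylic acid or a longer chain ending in a dimethylamino group on this carbon would give a number clearly apart from that of compound 3.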